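Aryl swap repeated on the second core

The source may hold more compounds than are shown below. What is called first, only, known or untested is meant among the compounds shown, and "the series" means these compounds.

Compound 1 `COc1cc(OC)cc(-c2cccc(NC(=O)CCc3ccc4c(c3)COB4O)c2)c1` and compound 2 `CC(=O)c1ccc(-c2cccc(NC(=O)CCc3ccc4c(c3)COB4O)c2)cc1` share one core and differ by 4-acetylphenyl in place of 3,5-dimethoxyphenyl on an aromatic carbon. In a functional assay on HCT-116 cells (Homo sapiens) for antiproliferative activity, read by MTT assay, with a stated time of 72 h (a higher number here means a weaker inhibitor, a lower number a stronger inhibitor), compound 1 gives 56000 nM, and compound 2 gives 63000 nM, so the change made a 1.1-fold higher number from compound 1 to compound 2 (0.05 log units; within the scatter). Compound 3 `COc1cc(OC)cc(-c2cccc(NC(=O)CCc3cccc4c3COB4O)c2)c1` keeps the 3,5-dimethoxyphenyl on a second core, differing from compound 1 by a group of 10 heavy atoms (7 carbon, 1 boron, 2 oxygen; one five-membered non-aromatic ring with 2 hetero atoms, one six-membered aromatic ring of carbon only) in place of a group of 10 heavy atoms (7 carbon, 1 boron, 2 oxygen; one five-membered non-aromatic ring with 2 hetero atoms, one six-membered aromatic ring of carbon only), on a saturated chain carbon, two bonds along the chain from a carbonyl carbon; in this assay compound 3 gives 50000 nM, a step of a 1.1-fold lower number from compound 1 to compound 3 (0.05 log units; within the scatter). Compound 4 `CC(=O)c1ccc(-c2cccc(NC(=O)CCc3cccc4c3COB4O)c2)cc1`, not yet measured, differs from compound 3 by 4-acetylphenyl in place of 3,5-dimethoxyphenyl on an aromatic carbon, at a place described in the same words as for the first pair, so this is the same change. For compound 4 the step in this assay is expected to be about a 1.1-fold higher number from compound 3 to compound 4 (0.05 log units; within the scatter). This rests on the first pair, where the change gave a 1.1-fold higher number from compound 1 to compound 2 (0.05 log units; within the scatter), and on the core swap giving a 1.1-fold lower number from compound 1 to compound 3 (0.05 log units; within the scatter). Compound 4 is therefore estimated at 56000 nM, between 30000 nM and 100000 nM.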

Compound 4, half-maximal inhibitory concentration: 48000 nM
Compound 4: middle estimate off by 1.2-fold (0.07 log units), on the high side, and the stated range covers the measured number.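

On the second core, the aryl swap gives a 1.0-fold lower number from compound 3 to compound 4 (0.02 log units; within the scatter) in this assay, and the two cores show no difference for this change: the same change on two cores in this assay, a 1.1-fold higher number (0.05 log units; within the scatter) from compound 1 to compound 2 and a 1.0-fold lower number (0.02 log units; within the scatter) from compound 3 to compound 4, 1.2-fold (0.07 log units) apart, within the scatter of two such steps
With 4-acetylphenyl in place of 3,5-dimethoxyphenyl, the core swap gives a 1.3-fold lower number from compound 2 to compound 4 (0.12 log units; within the scatter), and it too matches its earlier step: the same change on two cores in this assay, a 1.1-fold lower number (0.05 log units; within the scatter) from compound 1 to compound 3 and a 1.3-fold lower number (0.12 log units; within the scatter) from compound 2 to compound 4, 1.2-fold (0.07 log units) apart, within the scatter of two such steps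
Going by these compounds alone, this shows that both changes stay within the scatter on these four compounds, but it does not show that a change with a real effect would carry from one core to the other, as no step here lies beyond the scatter.

Still open, going by these compounds, is how an amine or a carboxylic acid on the aryl ring would behave on either core. On these data alone, the effect of a longer chain in place of the saturated chain is also open.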